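This account rests on a few compounds, and the source may have more. Where it says the series, first, only, none or still open, it means among the compounds named here.

Measured so far in a functional assay on K562 cells (Homo sapiens) for antiproliferative activity, read by MTT assay, with a stated time of 72 h; a higher number here means a weaker inhibitor, a lower number a stronger inhibitor:
compound 1, `COc1cc(-c2ncnn2-c2cccc(N)c2)cc(OC)c1OC`: > 10000 nM
compound 2, `COc1ccc(-n2ncnc2-c2cc(OC)c(OC)c(OC)c2)cc1`: 3600 nM
compound 3, `COc1cc(-n2ncnc2-c2ccc(F)cc2)cc(OC)c1OC`: > 10000 nM

Compound 1 gives only a limit of the assay. Compound 3 likewise gives only a limit. Within the data shown here, compound 2 is thus the one compound with a measured number; the other two values shown are limits, as the evidence on the series records: the limit of > 10000 nM in this assay, at which 2 of the 3 values shown sit.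

Compound 4, `COc1cc(-c2ncnn2-c2ccc(F)cc2)cc(OC)c1OC`, is not yet measured. It differs from compound 2 in one place: fluoro in place of methoxy on an aromatic carbon. The group leaving is methoxy, the group entering is fluoro, on an aromatic carbon of a six-membered aromatic ring of carbon only, para to a large group.

Among the measured compounds shown here, one measured step bears on changes of the ring attached to the aromatic nitrogen: an at least 2.7-fold lower number from compound 1 to compound 2 (0.44 log units; beyond the scatter), where 4-methoxyphenyl replaced 3-aminophenyl and the number fell from a limit to a measured value. For the measured compounds named here, compound 3, which carries 4-fluorophenyl on a carbon of the shared core rather than the nitrogen, also sits at the limit, but no single step connects it to compound 2 or compound 4. Removing the 4-methoxyphenyl from compound 2 is therefore expected to cost potency: compound 4 is estimated at 10000 nM, in the range 3000 nM to 30000 nM, a step of a 2.8-fold higher number from compound 2 to compound 4 (0.44 log units; beyond the scatter), with a fair chance that this assay reports only a limit.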

Compound 4, half-maximal inhibitory concentration: > 10000 nM
Compound 4: a limit, no number (the forecaster's own chance of this, stated with the estimate: 55%); the middle value sits exactly at the limit.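

In this assay, the change from 4-methoxyphenyl to 4-fluorophenyl on the aromatic nitrogen gives an at least 2.7-fold higher number from compound 2 to compound 4 (0.44 log units; beyond the scatter). This pair therefore isolates the methoxy group, para to a large group, as the single difference between a measured number and a limit. Compound 1 and compound 4 both stand as limits, so the step between them cannot be read and 3-aminophenyl and 4-fluorophenyl cannot be ordered; compound 2 remains the only measured number in the series: the limit of > 10000 nM in this assay, at which 3 of the 4 values shown sit.

As far as these compounds go, the size of the loss stays open, as compound 4 gives only a limit. Also open, from the compounds shown here alone, is whether a number survives at this place with an ethoxy group, a hydroxyl group or an amine, and whether methoxy is needed there at all.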